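Series notes: methyl to propyl on the 1,2-oxazol-5-yl group

A few compounds are considered here, and "the series" means these few. Any claim that something is new, unique, unknown or untested is made for them only; others in the source may bear on it.

Measured so far in a functional assay on NCI-H23 cells (Homo sapiens) for cytotoxicity, read by sulforhodamine B assay, tested at 10 uM; on this read-out lower numbers stand for less inhibition and higher numbers for more inhibition at the one concentration tested (going by the name of the read-out):
- compound 1 `CCCCc1ccc(-c2cc(-c3cn([C@H]4C[C@H](OC(C)=O)[C@@H](COC(C)=O)O4)c(=O)[nH]c3=O)on2)cc1` gives 97.4%
- compound 2 `O=c1[nH]c(=O)n([C@H]2C[C@H](O)[C@@H](CO)O2)cc1-c1cn(Cc2ccccc2)nn1` gives 97.5%
- compound 3 `CC(=O)OC[C@H]1O[C@@H](n2cc(-c3cc(C)no3)c(=O)[nH]c2=O)C[C@@H]1OC(C)=O` gives 101%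

Compound 3 holds the highest of the three numbers in this assay, but its nearest neighbour compound 2 sits within the scatter, as does compound 1, so the three cannot be ordered. Within the data shown here, the one single-point step recorded, a number 3.6 percentage points higher from compound 1 to compound 3 (within the scatter), is within the scatter and touches the same aromatic carbon of the 1,2-oxazol-5-yl group that is altered next.

Compound 4 `CCCc1cc(-c2cn([C@H]3C[C@H](OC(C)=O)[C@@H](COC(C)=O)O3)c(=O)[nH]c2=O)on1` differs from compound 3 by ethyl in place of hydrogen on a saturated chain carbon bound to an aromatic carbon. The change reads as methyl to propyl, or 3-methyl-1,2-oxazol-5-yl to 3-propyl-1,2-oxazol-5-yl, on the shared core of compound 3.

Among the measured compounds shown here, the only step that bears on this position is a number 3.6 percentage points higher from compound 1 to compound 3 (within the scatter), and a far larger swap there left this assay unmoved beyond the scatter. No step beyond the scatter is therefore expected for a number 3 percentage points lower from compound 3 to compound 4 (within the scatter), with the number staying near the top of the range seen so far. Compound 4 is accordingly estimated at 98% in this assay, between 88% and 104%.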

Compound 4, a percentage reported as inhibition, at one concentration (the size of the read-out at that concentration, not a potency): 96.9%
Compound 4: middle estimate off by 1.1 percentage points, on the high side, within the range that was stated.
By their numbers in this assay, from the lowest: compounds 4, 1, 2 and 3 (each within the scatter of the next).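

Extending methyl to propyl on the saturated chain carbon bound to an aromatic carbon gives a number 4.1 percentage points lower from compound 3 to compound 4 (within the scatter) in this assay, which adds a reading for a simple alkyl change to the earlier swap of a far larger group at this position. Compared with the 4-butylphenyl group, propyl gives a number 0.5 percentage points lower from compound 1 to compound 4 (within the scatter), so methyl, propyl and 4-butylphenyl cannot be told apart on this read-out at the one concentration tested. No supporting evidence bears on this result.

All three values lie close together, so the compounds shown leave open whether this position accepts change more widely or whether this single-concentration read-out cannot separate compounds at this level of inhibition. Going by these compounds, how an amine, a carboxylic acid or a longer chain in place of propyl would read in this assay also remains open.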